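The source may report more compounds than this note shows. Statements on the series, on what has been measured and on what is new or still open speak of the compounds shown alone.

Compound 1, `COc1ccc(-c2cc(/C=C/C(=O)c3cc(OC)c(OC)c(OC)c3)nc3cc(-c4ccccc4)nn23)cc1OC`, gives 35000 nM in an ADME assay on HEK293 cells (Homo sapiens) for antiproliferative activity, read by MTT assay, with a stated time of 24 h; on this read-out higher numbers stand for weaker inhibition and lower numbers for stronger inhibition.
Compound 2, `COc1ccc(C(=O)/C=C/c2cc(-c3ccc(OC)c(OC)c3)n3nc(-c4ccccc4)cc3n2)cc1`, gives 40000 nM in this assay.

These two numbers sit within the usual scatter of each other: the step of a 1.1-fold higher number from compound 1 to compound 2 (0.06 log units; within the scatter) is too small to count as a real change, so compound 2 cannot be told apart from compound 1 on this read-out, and the two together mark the only range the data show.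

Compound 3, `COc1ccc(-c2cc(/C=C/C(=O)c3ccc(Cl)cc3)nc3cc(-c4ccccc4)nn23)cc1OC`, differs from compound 2 in one place: chloro in place of methoxy on an aromatic carbon, para to a large group. Going by the values given here, the only measured step, from compound 1 to compound 2, also altered this same aryl group on the carbonyl carbon and left the number essentially unchanged. Among the compounds with values here, no measured step swaps a methoxy for a chloro, so there is nothing to point to a shift in either direction. The step of no change at the digits printed from compound 2 to compound 3 (within the scatter) is therefore expected to stay within the scatter. Compound 3 is estimated at 40000 nM, within a range of 15000 nM to 100000 nM.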

Compound 3, half-maximal inhibitory concentration: 44100 nM
Beside the measured number, compound 3's estimate is 1.1-fold (0.04 log units) below it; the range from low to high includes it.
By their numbers in this assay, from the lowest: compounds 1, 2 and 3 (each within the scatter of the next).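

Putting chloro in place of methoxy on an aromatic carbon, para to a large group, gives a 1.1-fold higher number from compound 2 to compound 3 (0.04 log units; within the scatter) in this assay, so at this place the two groups cannot be told apart on this read-out, even though chloro has no hydrogen-bond acceptor and methoxy has one. This is also the first aryl group on the carbonyl carbon without any methoxy, and the comparison with the 3,4,5-trimethoxyphenyl group of compound 1 gives a 1.3-fold higher number from compound 1 to compound 3 (0.10 log units; within the scatter), so all three aryl groups shown here fall within the scatter of one another. No separate measurement offers an explanation for why these numbers sit so close together.

The only groups shown at this para place are methoxy and chloro, so it remains open whether an amine, a carboxylic acid or a longer chain such as butoxy would move the number beyond the scatter. Also open, on these data alone, is whether a change elsewhere, such as replacing the ethenyl link to the carbonyl or the phenyl on the shared core, would matter more than changes to this aryl group.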